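A few compounds are considered here, and "the series" means these few. Any claim that something is new, unique, unknown or untested is made for them only; others in the source may bear on it.

Working notes on the series.

Compound 1 `C=C(C)C(=O)NCCOc1ccc(Oc2c(-c3ccc(F)cc3)sc3cc(O)ccc23)cc1` is known in a functional assay on Ishikawa cells (Homo sapiens) for antiproliferative activity, read by CCK-8 assay, with a stated time of 48 h (on this read-out higher numbers stand for weaker inhibition and lower numbers for stronger inhibition), only as a limit of the assay and not as a number: compound 1 gives > 25000 nM. Compound 2 `CN(C)C(=O)/C=C/CNCCOc1ccc(Oc2c(-c3ccc(F)cc3)sc3cc(O)ccc23)cc1` gives 11900 nM in this assay. Compound 3 `O=C(CCCNCCOc1ccc(Oc2c(-c3ccc(F)cc3)sc3cc(O)ccc23)cc1)N1CCC1` is likewise a limit of the assay: compound 3 gives > 25000 nM.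

Among the measured steps, an at least 2.1-fold lower number from compound 1 to compound 2 (0.32 log units; beyond the scatter), a step that the two limits leave unreadable from compound 1 to compound 3 and an at least 2.1-fold higher number from compound 2 to compound 3 (0.32 log units; beyond the scatter). Among the measured compounds shown here, the picture is thin because of the limit of > 25000 nM in this assay, at which 2 of the 3 values shown sit, so compound 1 can only be placed at the limit, with compound 2 the single numbered value.

Compound 4 `C=C(C)C(=O)N1CC(Oc2ccc(Oc3c(-c4ccc(F)cc4)sc4cc(O)ccc34)cc2)C1` differs from compound 1 by 1-((1-methylethenyl)carbonyl)azetidin-3-yl in place of 2-(((1-methylethenyl)carbonyl)amino)ethyl on an oxygen on an aromatic ring. For the measured compounds named here, none of the measured steps touches this place; all three vary what hangs on the amine nitrogen, whereas here the 2-(((1-methylethenyl)carbonyl)amino)ethyl chain becomes a 1-((1-methylethenyl)carbonyl)azetidin-3-yl ring on the aromatic oxygen. No step shown speaks for or against it, so compound 4 is expected to stay near the limit, with an expected step of an at least 1.2-fold lower number from compound 1 to compound 4 (0.09 log units; that floor lies within the scatter). The estimate for compound 4 is 20000 nM, within 8000 nM to 50000 nM.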

Compound 4, half-maximal inhibitory concentration: 14200 nM
Estimate against measurement, compound 4: 1.4-fold (0.15 log units) above, within the range that was stated.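

In this assay, compound 4 gives the first reading for a change on the aromatic oxygen itself: the 1-((1-methylethenyl)carbonyl)azetidin-3-yl ring in place of the open chain gives an at least 1.7-fold lower number from compound 1 to compound 4 (0.24 log units; that floor lies within the scatter), so this step is not shown to exceed the scatter. The comparison with the amine-bearing chain of compound 3 gives the same reading: an at least 1.7-fold lower number from compound 3 to compound 4 (0.24 log units; that floor lies within the scatter). Against the other numbered compound the result is a 1.2-fold higher number from compound 2 to compound 4 (0.08 log units; within the scatter), so the azetidine-bearing compound 4 and the amine-bearing compound 2 cannot be told apart in this read-out.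

On these data alone, the true distance of compound 1 and compound 3 from the numbered compounds stays unknown because of the limit: the limit of > 25000 nM in this assay, at which 2 of the 4 values shown sit. Whether a piperidine ring, or a free amine on the azetidine in place of the (1-methylethenyl)carbonyl group, moves the number beyond the scatter stays open.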